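A few compounds are considered here, and "the series" means these few. Any claim that something is new, unique, unknown or untested is made for them only; others in the source may bear on it.

Working notes on the series. Going by the values given here, compound 2 `O=C1NC(=O)C(Cc2ccc(Cc3ccccc3)cc2)S1` gives 9280 nM in a functional assay for agonist activity at Free fatty acid receptor 1 (Homo sapiens), read by FLIPR, in the presence of a further agent that is not named here (on this read-out lower numbers stand for an effect already at smaller amounts and higher numbers for an effect only at larger amounts of compound), the highest of the three numbers measured so far. Compound 3 `O=C1NC(=O)C(Cc2ccc(CCc3ccccc3)cc2)S1` gives 1080 nM, and compound 1 `Cc1cccc(Oc2ccc(CC3SC(=O)NC3=O)cc2)c1` gives 203 nM. Among the compounds with values here, the only step between measured compounds that differ in one place is an 8.6-fold lower number from compound 2 to compound 3 (0.93 log units; beyond the scatter); lengthening the link between the two aromatic rings by one chain carbon moved the read-out beyond the scatter. Within the data shown here, compound 1 and compound 2 differ in more than one place, so their two values show only that an oxygen-linked analogue carrying a methyl sits far lower than compound 2.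

Compound 4 `O=C1NC(=O)C(Cc2ccc(Sc3ccccc3)cc2)S1` has not yet been measured. It differs from compound 2 by phenylsulfanyl in place of benzyl on an aromatic carbon. Among the measured compounds shown here, no measured pair isolates this exchange. The step from compound 2 to compound 3 shows the read-out moving well beyond the scatter on a change at the link, and compound 1 shows that a heteroatom-linked analogue can sit far lower, though its methyl confounds that reading. A lower number is therefore expected for compound 4, roughly a 15-fold lower number from compound 2 to compound 4 (1.19 log units; beyond the scatter), with wide uncertainty given the lack of a direct comparator. The estimate for compound 4 in this assay is 600 nM, expected to lie between 150 nM and 2500 nM.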

Compound 4, half-maximal effective concentration: 5060 nM
Compound 4: middle estimate off by 8.4-fold (0.93 log units), on the low side; the whole stated range lies below it.
By their numbers in this assay, from the lowest: compound 1; then compound 3; then compounds 4 and 2 (each within the scatter of the next).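

In this assay, phenylsulfanyl in place of benzyl on an aromatic carbon, para to a group of 8 heavy atoms, gives a result that stays within the scatter (a 1.8-fold lower number from compound 2 to compound 4 (0.26 log units; within the scatter)). Going by these compounds alone, this is the first reading of a sulfur in the link at this position: the exchange keeps the heavy-atom count and adds one hydrogen-bond acceptor, yet compound 4 cannot be told apart from compound 2, whereas the longer chain of compound 3 gave a step beyond the scatter (an 8.6-fold lower number from compound 2 to compound 3 (0.93 log units; beyond the scatter)). Nothing measured here bears on why this exchange leaves the read-out within the scatter.

Compound 1 (203 nM) carries both an oxygen in the link and a methyl on the outer ring, and the compounds shown do not separate these two features. Also open, going by these compounds, is how an amine or a carbonyl as the link, or a longer chain carrying the sulfur, would read against phenylsulfanyl at this position.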